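The source may report more compounds than this note shows. Statements on the series, on what has been measured and on what is new or still open speak of the compounds shown alone.

Compound 1 `O=c1[nH]c(=O)n([C@H]2C[C@H](O)[C@@H](CO)O2)cc1-c1cn(Cc2ccccc2)nn1`: 103%
Compound 2 `CCCc1cc(-c2cn([C@H]3C[C@H](OC(C)=O)[C@@H](COC(C)=O)O3)c(=O)[nH]c2=O)on1`: 102%

Both were tested in a functional assay on MDA-MB-231 cells (Homo sapiens) for cytotoxicity, read by sulforhodamine B assay, tested at 10 uM; a lower number here means less inhibition, a higher number more inhibition at the concentration tested (going by the name of the read-out). Compound 2 gives 102% and compound 1 gives 103%, so the two stand within the usual scatter of each other, and both appear to inhibit the cells almost completely at the concentration tested. Compound 3 `CC(=O)OC[C@H]1O[C@@H](n2cc(-c3cc(-c4ccc(C(C)C)cc4)no3)c(=O)[nH]c2=O)C[C@@H]1OC(C)=O` is not yet measured. It differs from compound 2 in one place: 4-isopropylphenyl in place of propyl on an aromatic carbon. Among the measured compounds shown here, no measured pair shows what such a change does here. Since compound 2 gives 102%, compound 3 is expected to remain near the same level, with a step of a number 4 percentage points lower from compound 2 to compound 3 (within the scatter) expected to stay within the scatter. For compound 3 the estimate is 98%, within 85% to 105%.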

Compound 3, a percentage reported as inhibition, at one concentration (the size of the read-out at that concentration, not a potency): 83.2%
For compound 3 the middle estimate is 14.8 percentage points above the measured one; measured number below the stated range.
By their numbers in this assay, from the lowest: compound 3; then compounds 2 and 1 (each within the scatter of the next).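

The aromatic carbon of the five-membered ring is not indifferent to its substituent: in this assay, 4-isopropylphenyl in place of propyl gives a real drop (a number 18.8 percentage points lower from compound 2 to compound 3 (beyond the scatter)). Even so, compound 3 keeps substantial inhibition at 83.2%. Nothing available here accounts for the drop. Going by these compounds, it remains open whether a plain phenyl, a longer chain such as hexyl, or an amine at this carbon would read closer to compound 2 or to compound 3. A single tested concentration also leaves the potency of these compounds unknown.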